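The compounds below may be only part of what the source reports. "The series", "measured", "known", "first", "only" and "open" are said of these compounds alone.

In an ADME assay on Vero cells (Chlorocebus sabaeus) for cytotoxicity, read by CellTiter-Glo, with a stated time of 72 h (on this read-out lower numbers stand for higher toxicity in this test and higher numbers for lower toxicity in this test), compound 1 `CCNc1n[n+]([O-])c2ccccc2[n+]1[O-]` gives 17 ug/mL and compound 2 `CCCC(C)Nc1n[n+]([O-])c2ccccc2[n+]1[O-]` gives 26 ug/mL. The step between them is a 1.5-fold higher number from compound 1 to compound 2 (0.18 log units; within the scatter). Compound 3 `COCC(C)Nc1n[n+]([O-])c2ccccc2[n+]1[O-]` gives > 50 ug/mL, which is a limit and not a number. For compound 3 this is the limit of > 50 ug/mL in this assay, at which 1 of the 3 values shown sits. Compound 4 `CC(C)CCC(C)Nc1n[n+]([O-])c2ccccc2[n+]1[O-]` carries isobutyl in place of methoxy on a saturated chain carbon, two bonds along the chain from a nitrogen on an aromatic ring. The closest measured change runs the other way, methoxy in place of ethyl, and it is an at least 1.9-fold higher number from compound 2 to compound 3 (0.28 log units; that floor lies within the scatter). The other step into compound 3 is an at least 2.9-fold higher number from compound 1 to compound 3 (0.46 log units; beyond the scatter). Like compound 2, at 26 ug/mL, compound 4 has no methoxy, so it is expected to fall near that level. The estimated step is an at least 2.5-fold lower number from compound 3 to compound 4 (0.39 log units; beyond the scatter), towards a lower number in this assay. Compound 4 is estimated at 20 ug/mL, with an expected range of 9 ug/mL to 45 ug/mL.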

Compound 4, half-maximal cytotoxic concentration: 4.1 ug/mL
For compound 4 the middle estimate is 4.9-fold (0.69 log units) above the measured one, outside the stated range (below it).
By their numbers in this assay, from the lowest: compound 4; then compounds 1 and 2 (each within the scatter of the next). At a limit, above all of these: compound 3.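

The longer branched chain changes the read-out where the shorter one did not: isopentyl on the chain carbon gives a 4.1-fold lower number from compound 1 to compound 4 (0.62 log units; beyond the scatter), so compound 4 is the most toxic of the compounds shown. Isopropyl in place of methyl further along the chain gives a 6.3-fold lower number from compound 2 to compound 4 (0.80 log units; beyond the scatter). Isobutyl in place of methoxy gives an at least 12-fold lower number from compound 3 to compound 4 (1.08 log units; beyond the scatter), which is only a floor, since one end of that step is a limit: the limit of > 50 ug/mL in this assay, at which 1 of the 4 values shown sits.

The compounds shown do not separate chain length from branching. As far as these compounds go, how a longer straight chain, or a chain ending in an amine or a carboxylic acid, would read here remains open.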